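Removing one chloro from compound 1 in the series

This account rests on a few compounds, and the source may have more. Where it says the series, first, only, none or still open, it means among the compounds named here.

Within the data shown here, compound 1 `NC1=NC2(CCSCC2)N(OCCCOc2ccc(Cl)c(Cl)c2)C(N)=N1` is the only member with a numerical result: in a functional assay on HepG2 cells (Homo sapiens) for antiproliferative activity, read by MTT assay, with a stated time of 72 h (on this read-out higher numbers stand for weaker inhibition and lower numbers for stronger inhibition), compound 1 gives 70 nM. Compound 2 `NC1=NC2(CCOCC2)N(OCCCOc2cc(Cl)c(Cl)cc2Cl)C(N)=N1` carries no result in this assay ("not determined" (no result reported)). Compound 3 `NC1=NC2(CCSCC2)N(OCCCOc2ccc(Cl)cc2)C(N)=N1` differs from compound 1 by hydrogen in place of chloro on an aromatic carbon. Among the measured compounds shown here, no pair of measured compounds differing in a single place is available, so this step has no precedent in the set. Loss of one chloro is expected to cost some potency, a step of a 2.3-fold higher number from compound 1 to compound 3 (0.36 log units; beyond the scatter) somewhat beyond the usual scatter, toward weaker inhibition. Compound 3 is therefore expected to give 160 nM, within 55 nM to 500 nM.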

Compound 3, half-maximal inhibitory concentration: 1100 nM
Beside the measured number, compound 3's estimate is 6.9-fold (0.84 log units) below it; the measured number lies above the stated range.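

Going from 3,4-dichlorophenyl to 4-chlorophenyl gives a 16-fold higher number from compound 1 to compound 3 (1.20 log units; beyond the scatter) in this assay, so a single heavy atom on this aromatic carbon, ortho to a chloro group and meta to a large group, accounts for a large share of the potency of compound 1. The chloro that stays in compound 3 does not make up for the one that leaves. Nothing available bears on the reason for a step of this size.

Open, going by these compounds, is whether fluoro, methyl or methoxy on this carbon would keep the potency of compound 1. Also open, on these data alone, is whether a step of this size would recur on a different core.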